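Changing the Benzyl Ether in the Strongest Compound

The source may hold more compounds than are shown below. What is called first, only, known or untested is meant among the compounds shown, and "the series" means these compounds.

Compound 1 `Cc1cccc(COc2ccc(/C=C/C(/C=C/c3ccccn3)=N/Oc3ncnc4cccc(C)c34)cc2)c1`: 93.4%
Compound 2 `Cc1cccc(COc2ccc(/C=C/C(/C=C/c3ccccn3)=N/Oc3ncnc4ccccc34)cc2)c1`: 69.2%
Compound 3 `Cc1cccc(COc2ccc(/C=C/C(/C=C/c3ccccn3)=N/Oc3ncnc4cc(Cl)ccc34)cc2)c1`: 78.6%

In a functional assay on SMMC-7721 cells (Homo sapiens) for inhibition, read by MTT assay, with a stated time of 72 h, tested at 1 uM (a higher number here means a stronger effect of the compound at the concentration tested, a lower number a weaker effect), compound 1 stands highest of the three numbers. Both measured steps away from it lie beyond the scatter, a number 14.8 percentage points lower from compound 1 to compound 3 (beyond the scatter) and a number 24.2 percentage points lower from compound 1 to compound 2 (beyond the scatter), whereas a number 9.4 percentage points higher from compound 2 to compound 3 (within the scatter) lies within it. Compound 4 `Cc1cccc2ncnc(O/N=C(/C=C/c3ccc(OCc4ccccc4Cl)cc3)\C=C\c3ccccn3)c12` differs from compound 1 by 2-chlorophenyl in place of 3-methylphenyl on a saturated chain carbon bound to an oxygen on an aromatic ring. None of the three measured steps touches this part of the molecule; each of them alters the other ring system, so the data give no direct guide for this change. A step of modest size at most is therefore expected, a number 11.4 percentage points lower from compound 1 to compound 4 (beyond the scatter), with the direction uncertain. Compound 4 is expected to give 82% in this assay, within a range of 58% to 97%.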

Compound 4, a percentage reported as inhibition, at one concentration (the size of the read-out at that concentration, not a potency): 77%
Estimate against measurement, compound 4: 5 percentage points above; the range from low to high includes it.
By their numbers in this assay, from the lowest: compounds 2, 4 and 3 (each within the scatter of the next); then compound 1.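

Going by these compounds alone, compound 4 gives the first reading on the benzyl ether side of the molecule. In this assay, 2-chlorophenyl in place of 3-methylphenyl on a saturated chain carbon bound to an oxygen on an aromatic ring gives a number 16.4 percentage points lower from compound 1 to compound 4 (beyond the scatter), so this part of compound 1 also affects the read-out, not only the other ring system. Nothing available explains this step.

The exchange changes both the substituent and its place on the phenyl ring, and the compounds shown do not separate the two. They also leave open how a phenyl ring bearing an amine or a carboxylic acid would read.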